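Methyl in Place of Hydrogen on the Hydroxymethyl Arm

A few compounds are considered here, and "the series" means these few. Any claim that something is new, unique, unknown or untested is made for them only; others in the source may bear on it.

Among the measured compounds shown here, in an assay on isolated protein for inhibition of Polyunsaturated fatty acid 5-lipoxygenase (Homo sapiens) (a higher number here means a weaker inhibitor, a lower number a stronger inhibitor), compound 2 `CCC(O)(c1cn(Cc2ccc3c(-c4ccccc4)c(CO)sc3c2)nn1)C(F)(F)F` gives 19 nM, the lowest of the numbers measured so far. Compound 1 `CC[C@](O)(c1cn(Cc2ccc3c(-c4ccc(F)cc4)c(C(N)=O)sc3c2)nn1)C(F)(F)F` gives 55 nM, and compound 3 `CC[C@@](O)(c1cn(Cc2ccc3c(-c4ccc(F)cc4)c(C(N)=O)sc3c2)nn1)C(F)(F)F` gives 1160 nM. For the measured compounds named here, the only single-change step among the measured compounds, a 21-fold higher number from compound 1 to compound 3 (1.32 log units; beyond the scatter), is large and rests on (the fact that compounds 1 and 3 differ only in the configuration as drawn). Compound 4 `CCC(O)(c1cn(Cc2ccc3c(-c4ccccc4)c(C(C)O)sc3c2)nn1)C(F)(F)F` arises from compound 2 by methyl in place of hydrogen on a saturated chain carbon bound to an aromatic carbon and an oxygen on a saturated carbon. Going by the values given here, no measured step touches this place: the one step recorded concerns the configuration at a saturated chain carbon in a different part of the molecule, and the remaining differences between compound 2 and the other two compounds involve several groups at once, so they cannot be pulled apart. With no direct guide, adding a methyl at this position is expected to leave the number close to where compound 2 stands. The step expected is a 1.3-fold higher number from compound 2 to compound 4 (0.12 log units; within the scatter), not beyond the scatter. Compound 4 is therefore estimated at 25 nM, with a range from 8 nM to 80 nM.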

Compound 4, half-maximal inhibitory concentration: 88 nM
Compound 4: the middle estimate sits 3.5-fold (0.55 log units) below what was measured; measured number outside the range, above it.
By their numbers in this assay, from the lowest: compound 2; then compounds 1 and 4 (each within the scatter of the next); then compound 3.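

The hydroxymethyl arm is sensitive to even a small change: in this assay, going from hydroxymethyl to 1-hydroxyethyl gives a 4.6-fold higher number from compound 2 to compound 4 (0.67 log units; beyond the scatter), a modest step but one beyond the scatter. Among the compounds shown here, the earlier single-change step concerned only configuration at a different carbon, so this is the first direct reading at this place, and the added methyl moves the number towards a weaker inhibitor. Nothing available explains this shift, as the only structural fact on hand concerns a different part of the molecule.

From the compounds shown here alone, the carbon bearing the new methyl is drawn without configuration in compound 4, and configuration at another carbon gives a 21-fold higher number from compound 1 to compound 3 (1.32 log units; beyond the scatter), so how the two mirror-image forms at this carbon would compare remains open. Also open, going by these compounds, is how an ethyl chain, a methoxymethyl group or an aminomethyl group would read at this place.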